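Mirror image of a fluorocyclopropyl amide at the receptor

The source may hold more compounds than are shown below. What is called first, only, known or untested is meant among the compounds shown, and "the series" means these compounds.

Three amides sharing one bicyclic core have been measured in an assay on SH-EP1 cells for displacement of a labelled ligand from Neuronal acetylcholine receptor; alpha4/beta2 (Homo sapiens), read by scintillation counting; a lower number here means a stronger inhibitor, a higher number a weaker inhibitor. Compound 1 `CCC(=O)N1CC2CC(C1)N2` gives 6 nM in this assay, compound 2 `O=C(C1CCC1)N1CC2CC(C1)N2` gives 16 nM, and compound 3 `O=C([C@H]1C[C@H]1F)N1CC2CC(C1)N2` gives 1.1 nM. Compound 3 stands lowest of the three: relative to it, compound 1 is nearest, with a 5.5-fold lower number from compound 1 to compound 3 (0.74 log units; beyond the scatter) separating them, and compound 2 is furthest, as seen in a 15-fold lower number from compound 2 to compound 3 (1.16 log units; beyond the scatter). The step of a 2.7-fold higher number from compound 1 to compound 2 (0.43 log units; beyond the scatter) shows that the acyl group alone moves the number beyond the scatter.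

Compound 4 `O=C([C@@H]1C[C@@H]1F)N1CC2CC(C1)N2` differs from compound 3 only in configuration: the two compounds have the same atoms and bonds; at least one stereo element is drawn with a configuration in one of them and without one in the other: 2 of 4 stereo elements differ; a stereocentre at a saturated ring carbon is drawn R in compound 3 and S in compound 4; a stereocentre at a saturated ring carbon is drawn R in compound 3 and S in compound 4. Among the compounds with values here, none of the measured steps bears on this change, since each of them swaps the acyl group rather than inverting stereocentres. The steps involving compound 3 show only that the fluorocyclopropyl amide in that configuration is the strongest binder of the set; they give no guide to its mirror image. With no stereochemical comparison available, a weaker number is expected for compound 4, with wide uncertainty: the estimated step is a 5.5-fold higher number from compound 3 to compound 4 (0.74 log units; beyond the scatter). Compound 4 is therefore expected at 6 nM, within 1.2 nM to 40 nM.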

Compound 4, inhibition constant: 1.7 nM
Beside the measured number, compound 4's estimate is 3.5-fold (0.55 log units) above it; the measured number falls inside the stated range.
By their numbers in this assay, from the lowest: compounds 3 and 4 (each within the scatter of the next); then compound 1; then compound 2.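

In this assay, inverting both ring stereocentres of the 2-fluorocyclopropyl group leaves the number within the scatter (a 1.5-fold higher number from compound 3 to compound 4 (0.19 log units; within the scatter)), so at this position the receptor assay does not separate the two drawn configurations. The gain over the other acyl groups therefore does not depend on one configuration, for it persists against the cyclobutyl amide (a 9.4-fold lower number from compound 2 to compound 4 (0.97 log units; beyond the scatter)) and against the ethyl-bearing amide (a 3.5-fold lower number from compound 1 to compound 4 (0.55 log units; beyond the scatter)). This reading of the configuration carries one caution: (the fact that one of compounds 3 and 4 is drawn with a defined configuration and the other without, at the place where they differ).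

Going by these compounds, it remains open how a plain cyclopropyl amide would compare with compound 3 and compound 4, and so how much of their standing belongs to the fluorine. Also open, on these data alone, is whether a chlorine or a methyl group on that ring would keep the number as low.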